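The source may hold more compounds than are shown below. What is called first, only, known or untested is meant among the compounds shown, and "the series" means these compounds.

Of the compounds shown here, two of a shared core have been tested so far. Compound 1 `O=C(Nc1ccc2nc(NC(=O)C3CCCCC3)sc2c1)c1c(F)cccc1C(F)(F)F` is measured in a functional assay on WI-38 VA13 cells (Homo sapiens) for cytotoxicity (on this read-out higher numbers stand for an effect only at larger amounts of compound and lower numbers for an effect already at smaller amounts), where compound 1 gives 0.032 ug/mL. Compound 2 `CCCC(=O)Nc1nc2ccc(NC(=O)c3c(Cl)cccc3Cl)cc2s1` carries a different pair of groups on the same core; in this assay compound 2 gives 0.01 ug/mL. Of the two numbers, that of compound 2 is the lower one, and its gap to compound 1 lies beyond the usual scatter, so compound 2 stands as the more potent of the pair.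

Compound 3 `O=C(Nc1nc2ccc(NC(=O)c3c(Cl)cccc3Cl)cc2s1)OCc1ccccc1` is the next one to be measured. It differs from compound 2 in one place: benzyloxy in place of propyl on a carbonyl carbon. Among the compounds with values here, no measured pair shows this exact change, so its effect is unknown here. The expected step from compound 2 is a 3.0-fold higher number from compound 2 to compound 3 (0.48 log units; beyond the scatter), a modest loss that may still lie within the scatter. In this assay compound 3 is therefore expected to give about 0.03 ug/mL, somewhere between 0.008 ug/mL and 0.12 ug/mL.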

Compound 3, half-maximal effective concentration: 0.018 ug/mL
Compound 3: middle estimate off by 1.7-fold (0.22 log units), on the high side; low and high end bracket the measured number.
By their numbers in this assay, from the lowest: compounds 2, 3 and 1 (each within the scatter of the next, the first and the last beyond it).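

In this assay, putting benzyloxy in place of propyl on a carbonyl carbon gives a 1.8-fold higher number from compound 2 to compound 3 (0.26 log units; within the scatter). The incoming group has 8 heavy atoms against 3, along with an aromatic ring and a hydrogen-bond acceptor, yet this read-out cannot tell compound 2 and compound 3 apart, so for this one pair, the added bulk of atoms leaves no effect clear of the scatter. No accompanying measurement offers an explanation for this result.

Because the ring and the oxygen enter together, this single pair cannot show what each contributes; a benzyl group, which has the ring without the oxygen, would separate the two. Going by these compounds, how an amine or a longer carbon chain on the same carbonyl carbon would read in this assay also remains open.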